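This account rests on a few compounds, and the source may have more. Where it says the series, first, only, none or still open, it means among the compounds named here.

Compound 3 `O=C(C1=C(Nc2cccc(Br)c2)C(=O)N(CCCn2ccnc2)C1c1ccc(Br)cc1)c1ccccc1` gives 15800 nM in a functional assay on A549 cells (Homo sapiens) for antiproliferative activity, read by MTT assay, with a stated time of 72 h; on this read-out higher numbers stand for weaker inhibition and lower numbers for stronger inhibition. Its number sits second highest of the three measured, though the step of a 1.4-fold lower number from compound 2 to compound 3 (0.15 log units; within the scatter) lies within the scatter: compound 2 `O=C(C1=C(Nc2ccc(Br)cc2)C(=O)N(CCCn2ccnc2)C1c1ccc(Br)cc1)c1ccccc1` gives 22200 nM in this assay, and compound 1 `CCCCCOC1=C(C(=O)c2ccccc2)C(c2ccc(Br)cc2)N(CCCn2ccnc2)C1=O` gives 7290 nM. The steps of a 3.0-fold higher number from compound 1 to compound 2 (0.48 log units; beyond the scatter) and a 2.2-fold higher number from compound 1 to compound 3 (0.34 log units; beyond the scatter) are both modest and beyond the scatter. Compound 4 `O=C(C1=C(Nc2ccccc2Br)C(=O)N(CCCn2ccnc2)C1c1ccc(Br)cc1)c1ccccc1` differs from compound 3 by 2-bromophenyl in place of 3-bromophenyl on an amine nitrogen. The measured step that bears most directly on this change is a 1.4-fold lower number from compound 2 to compound 3 (0.15 log units; within the scatter), in which the bromophenyl group on the amine nitrogen was likewise exchanged for another bromophenyl group, and it stayed within the scatter. The two other steps replaced pentyloxy and do not touch the group on the amine nitrogen, so they say little about this change. On that basis the expected step of a 1.1-fold lower number from compound 3 to compound 4 (0.02 log units; within the scatter) is none beyond the scatter. Compound 4 is therefore estimated at 15000 nM, with a range from 6000 nM to 40000 nM.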

Compound 4, half-maximal inhibitory concentration: 20100 nM
For compound 4 the middle estimate is 1.3-fold (0.13 log units) below the measured one; low and high end bracket the measured number.
By their numbers in this assay, from the lowest: compound 1; then compounds 3, 4 and 2 (each within the scatter of the next).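

Moving the bromine to give 2-bromophenyl on the amine nitrogen completes the set of three bromophenyl groups at this place, and in this assay the set does not separate: a 1.3-fold higher number from compound 3 to compound 4 (0.10 log units; within the scatter) and a 1.1-fold lower number from compound 2 to compound 4 (0.04 log units; within the scatter) both lie within the scatter. Compound 4 also falls in line with the other two compounds that carry a bromophenylamino group, with a 2.8-fold higher number from compound 1 to compound 4 (0.44 log units; beyond the scatter), so among these four compounds the modest gap lies between pentyloxy and the bromophenylamino groups rather than among those groups. Nothing available here accounts for either observation.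

These compounds leave open whether a plain phenyl, or a methoxy group or a carboxylic acid in place of the bromine, would shift the number at this place. They also leave open how a shorter or longer chain than pentyloxy would compare.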